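Dropping a fluoro group from compound 2

A few compounds are considered here, and "the series" means these few. Any claim that something is new, unique, unknown or untested is made for them only; others in the source may bear on it.

Of the compounds shown here, three sharing one core have been tested in a functional assay on A549 cells (Homo sapiens) for cytotoxicity, read by MTT assay, with a stated time of 48 h; on this read-out higher numbers stand for weaker inhibition and lower numbers for stronger inhibition. Compound 1 `COc1cc(-c2nnc3n2NC(c2cccs2)C(C(=O)c2ccc(C)cc2)S3)cc(OC)c1OC` gives 12700 nM in this assay. Compound 3 `COc1cc(-c2nnc3n2NC(c2cccs2)C(C(=O)c2ccc(Cl)cc2)S3)cc(OC)c1OC`, which carries chloro in place of methyl on an aromatic carbon, gives 20100 nM; the step of a 1.6-fold higher number from compound 1 to compound 3 (0.20 log units; within the scatter) is too small to count as a real change. Compound 2 `COc1cc(-c2nnc3n2NC(c2ccco2)C(C(=O)c2ccccc2F)S3)cc(OC)c1OC` gives 78700 nM, the highest of the three numbers, so among these it inhibits the growth of the cells least; its nearest neighbour on the numbers is compound 3, and compound 1 lies furthest from it.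

Compound 4 `COc1cc(-c2nnc3n2NC(c2ccco2)C(C(=O)c2ccccc2)S3)cc(OC)c1OC` is compound 2 with one change: hydrogen in place of fluoro on an aromatic carbon. Going by the values given here, no measured step touches this kind of change, since the only step in hand swaps chloro for methyl on a different part of the molecule and stays within the scatter. The carbonyl-bearing ring itself is otherwise untouched, and the furan shared by compounds 2 and 4 is not present in compounds 1 or 3, so nothing here shows how such a ring responds to a change on the benzoyl group.

Among the compounds with values here, with no guiding step, compound 4 is expected to land near compound 2, the expected step of a 1.3-fold lower number from compound 2 to compound 4 (0.12 log units; within the scatter) being no larger than the scatter but uncertain in direction. The estimate for compound 4 in this assay is 60000 nM, with a range from 20000 nM to 180000 nM.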

Compound 4, half-maximal inhibitory concentration: 33400 nM
Compound 4: middle estimate off by 1.8-fold (0.25 log units), on the high side; measured number inside the range.
By their numbers in this assay, from the lowest: compounds 1, 3 and 4 (each within the scatter of the next, the first and the last beyond it); then compound 2.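

In this assay, the change is a 2.4-fold lower number from compound 2 to compound 4 (0.37 log units; beyond the scatter), the first step shown at this place on the aromatic ring, ortho to a large group. It shows that this one heavy atom is enough to shift the number by more than the scatter, and that with the fluoro group gone, inhibition of cell growth is stronger, so in this furan-bearing pair the fluoro group brings no gain. Going by these compounds alone, the earlier step, a 1.6-fold higher number from compound 1 to compound 3 (0.20 log units; within the scatter), stayed within the scatter, but it was a different swap on a different pair of compounds, so the two steps show only that a small change on this part of the molecule can matter in one case and not in another, and no measurement in hand explains why.

From the compounds shown here alone, whether removing the fluoro group would give a similar step in compounds carrying the thiophene of compound 1 and compound 3 remains open. Going by these compounds, it is also open whether fluoro is special at this place or whether another group there, such as chloro, methyl, methoxy or an amine, would give a number like that of compound 2 or like that of compound 4.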